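This account rests on a few compounds, and the source may have more. Where it says the series, first, only, none or still open, it means among the compounds named here.

Compound 1 `Cc1cc(C)cc(S(=O)(=O)c2c(C(=O)N[C@@H]3CCN(Cc4n[nH]c(=O)n4C)C3)[nH]c3ccc(Cl)cc23)c1`: 22400 nM
Compound 2 `Cc1cc(C)cc(S(=O)(=O)c2c(C(=O)NC3CN(S(C)(=O)=O)C3)[nH]c3ccc(Cl)cc23)c1`: > 252000 nM

Both compounds were tested in an ADME assay on MT4 cells (Homo sapiens) for cytotoxicity, read by MTT assay, with a stated time of 5 days; a higher number here means that more compound is tolerated, a lower number that less compound is tolerated. Compound 1 gives 22400 nM. Compound 2 gives only a limit, > 252000 nM, not a number. Compound 2 thus stands at the limit of > 252000 nM in this assay, at which 1 of the 2 values shown sits. Compound 3 `Cc1cc(C)cc(S(=O)(=O)c2c(C(=O)NS(=O)(=O)c3ccccc3)[nH]c3ccc(Cl)cc23)c1` differs from compound 2 in a single place: phenylsulfonyl in place of 1-(methylsulfonyl)azetidin-3-yl on an amide-type nitrogen. Among the compounds with values here, no measured pair shows what this change does. In this assay a modest shift toward less tolerated compound is expected, though it may stay within the scatter. Compound 3 is estimated at 100000 nM, between 30000 nM and 252000 nM. The expected step is an at least 2.5-fold lower number from compound 2 to compound 3 (0.40 log units; beyond the scatter).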

Compound 3, half-maximal cytotoxic concentration: 167000 nM
For compound 3 the middle estimate is 1.7-fold (0.22 log units) below the measured one; the measured number falls inside the stated range.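

In this assay, phenylsulfonyl in place of 1-(methylsulfonyl)azetidin-3-yl on the amide-type nitrogen gives an at least 1.5-fold lower number from compound 2 to compound 3 (0.17 log units; that floor lies within the scatter). Within the data shown here, this is the first reading for a six-membered aromatic ring at this place, and compound 3 gives an actual number. The true size of the step stays unknown, as compound 2 gives only a limit: the limit of > 252000 nM in this assay, at which 1 of the 3 values shown sits.

The compounds shown do not separate the part played by the phenyl ring from that of the sulfonyl group. A benzoyl group on the same nitrogen would help to tell these apart.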